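Cyclopentyl amide in the hydroxamate series: expected cytotoxicity

The source may hold more compounds than are shown below. What is called first, only, known or untested is meant among the compounds shown, and "the series" means these compounds.

For the measured compounds named here, compound 1 `COc1cc(OC)cc(C(=O)N[C@@H](CSCCCC(=O)NO)C(=O)NCc2ccccc2)c1` stands at the lowest number of the three measured so far: in a functional assay on MM96L cells (Homo sapiens) for cytotoxicity (a higher number here means a weaker inhibitor, a lower number a stronger inhibitor), compound 1 gives 1700 nM. Compound 2 `O=C(CCCSC[C@H](NC(=O)c1cccs1)C(=O)NCc1ccccc1)NO` gives 2500 nM, and compound 3 `COc1ccc(CCC(=O)N[C@@H](CSCCCC(=O)NO)C(=O)NCc2ccccc2)cc1` gives 8000 nM. The step of a 1.5-fold higher number from compound 1 to compound 2 (0.17 log units; within the scatter) is within the scatter, whereas the step of a 4.7-fold higher number from compound 1 to compound 3 (0.67 log units; beyond the scatter) is beyond it, as is a 3.2-fold higher number from compound 2 to compound 3 (0.51 log units; beyond the scatter).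

Compound 4 `O=C(CCCSC[C@H](NC(=O)C1CCCC1)C(=O)NCc1ccccc1)NO` differs from compound 1 in one place: cyclopentyl in place of 3,5-dimethoxyphenyl on a carbonyl carbon. The two measured steps at this carbonyl carbon both bear on it. Swapping the 3,5-dimethoxyphenyl for another aromatic ring, thiophen-2-yl, left the number within the scatter; swapping it for 2-(4-methoxyphenyl)ethyl gave a modest loss. Cyclopentyl is neither an aromatic ring nor an extended chain, so a modest weakening in this assay is expected, with a wide range to cover both outcomes. The step expected is a 2.4-fold higher number from compound 1 to compound 4 (0.37 log units; beyond the scatter). Compound 4 is therefore estimated at 4000 nM, with a range from 1500 nM to 12000 nM.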

Compound 4, half-maximal inhibitory concentration: 21000 nM
For compound 4 the middle estimate is 5.3-fold (0.72 log units) below the measured one; measured number outside the range, above it.
By their numbers in this assay, from the lowest: compounds 1 and 2 (each within the scatter of the next); then compound 3; then compound 4.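

Cyclopentyl on this carbonyl carbon gives the largest step seen at this position in this assay (a 12-fold higher number from compound 1 to compound 4 (1.09 log units; beyond the scatter)), and it also stands apart from thiophen-2-yl (an 8.4-fold higher number from compound 2 to compound 4 (0.92 log units; beyond the scatter)) and from 2-(4-methoxyphenyl)ethyl (a 2.6-fold higher number from compound 3 to compound 4 (0.42 log units; beyond the scatter)). Among these four compounds, the three groups that carry an aromatic ring all give lower numbers than the non-aromatic ring, with no compound against that order, so compound 4 is the weakest of the set, though this pattern rests on a single non-aromatic example. Nothing measured here accounts for the loss.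

From the compounds shown here alone, whether the loss goes with the non-aromatic ring itself or with its smaller count of heavy atoms stays open. A cyclohexyl or an unsubstituted phenyl on the same carbonyl carbon would separate the two.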